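The compounds below may be only part of what the source reports. "The series", "measured", "known", "first", "only" and "open" are said of these compounds alone.

Measured in a functional assay on P388D1 cells (Homo sapiens) for antiproliferative activity, read by sulforhodamine B assay, with a stated time of 48 h; on this read-out higher numbers stand for weaker inhibition and lower numbers for stronger inhibition
compound 1 `O=C1NCCN1c1ccc(S(=O)(=O)Nc2ccc3[nH]ccc3c2)cc1` at 520 nM
compound 2 `CCc1cccc(NS(=O)(=O)c2ccc(N3CCNC3=O)cc2)c1` at 250 nM
compound 3 `O=C1NCCN1c1ccc(S(=O)(=O)Nc2cccc(Br)c2)cc1` at 90 nM

Compound 3 (at 90 nM) holds the lowest number of the three. Compound 2 (at 250 nM) lies above it, and compound 1 (at 520 nM) lies further above it still.

Next in the series is compound 4 `O=C1NCCN1c1ccc(S(=O)(=O)Nc2cccc(Cl)c2)cc1` with a single exchange. The count reads chloro in place of bromo on an aromatic carbon for chloro in place of bromo on an aromatic carbon, meta to a large group.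

Among the measured compounds shown here, only one measured step bears on this exchange: a 2.8-fold lower number from compound 2 to compound 3 (0.44 log units; beyond the scatter) with bromo in place of ethyl on an aromatic carbon. That step was modest. For the measured compounds named here, no measured compound carries chloro, so it gives no direct reading of the new exchange and serves only as a rough guide to size. Going from bromo to chloro is expected to move the number less than that step did.

In this assay the expected outcome is a slight rise that stays within the scatter (estimated as a 1.3-fold higher number from compound 3 to compound 4 (0.12 log units; within the scatter)) and the direction is only a weak lean. For compound 4 the estimated value is 120 nM with an expected range of 50 nM to 280 nM on this read-out.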

Compound 4, half-maximal inhibitory concentration: 78 nM
Compound 4: the middle estimate sits 1.5-fold (0.19 log units) above what was measured; low and high end bracket the measured number.
By their numbers in this assay, from the lowest: compounds 4 and 3 (each within the scatter of the next); then compound 2; then compound 1.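

Notes on the 3-chlorophenyl and 3-bromophenyl pair: in this assay, chloro in place of bromo on this aromatic carbon, meta to a large group, gives (a 1.2-fold lower number from compound 3 to compound 4 (0.06 log units; within the scatter)), so this read-out does not separate the two halogens at this position. Among the compounds shown here, compound 3 had previously been the only halogen example, and the chloro in place of ethyl exchange now gives (a 3.2-fold lower number from compound 2 to compound 4 (0.51 log units; beyond the scatter)), which, like (a 2.8-fold lower number from compound 2 to compound 3 (0.44 log units; beyond the scatter)), lies beyond the scatter, so the lower number relative to the ethyl compound is not confined to bromo. Nothing available explains why the two halogens read alike here or why both read lower than ethyl.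

Going by these compounds, it remains open whether this reading extends to fluoro, trifluoromethyl, methoxy, an amine or a carboxylic acid at the same position, and whether a longer chain would read closer to ethyl. On these data alone, it is also open whether chloro elsewhere on the same ring, or a parent ring with hydrogen at this position, would match the halogen pair.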